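Swapping the Amine Side Chain on the Shared Benzamide Core

The compounds below may be only part of what the source reports. "The series", "measured", "known", "first", "only" and "open" are said of these compounds alone.

Compound 1 `CN(C)CCN(CCN(C)C)c1ccc(C(=O)N2CCc3ccc(OS(N)(=O)=O)cc3C2)cc1` carries a bis(2-(dimethylamino)ethyl)amino group, and in an assay on HEK293 cells for inhibition of Steryl-sulfatase (Homo sapiens), tested at 0.1 uM (a higher number here means a stronger effect of the compound at the concentration tested, a lower number a weaker effect), compound 1 gives 3.8%. Among the three numbers available, this stands clearly below compound 2 `CCN(Cc1ccccc1)c1cccc(C(=O)N2CCc3ccc(OS(N)(=O)=O)cc3C2)c1`, which in this assay gives 17.3%, and within the scatter of compound 3 `CN(C)CCN(CCN(C)C)c1cccc(C(=O)N2CCc3ccc(OS(N)(=O)=O)cc3C2)c1`, for which this assay gives 0%. Among the compounds with values here, the one measured step that changes a single place runs a number 17.3 percentage points lower from compound 2 to compound 3 (beyond the scatter); the group entering there is the same one that compound 1 carries, and the lower number goes with it.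

Compound 4 `CN(CCCN1CCCCC1)c1ccc(C(=O)N2CCc3ccc(OS(N)(=O)=O)cc3C2)cc1` has not yet been measured. It differs from compound 1 as follows: methyl(3-(piperidin-1-yl)propyl)amino in place of bis(2-(dimethylamino)ethyl)amino on an aromatic carbon. Within the data shown here, no measured step exchanges this exact pair of groups, so the step from compound 2 to compound 3 is the only guide: read in the other direction, taking the bis(2-(dimethylamino)ethyl)amino group out recovered a modest amount, and the group entering in compound 4 contains a ring, as the group of compound 2 does, though a different one. A modest rise is therefore expected, with wide uncertainty, and the expected step is a number 5.2 percentage points higher from compound 1 to compound 4 (within the scatter). Compound 4 is estimated at 9% in this assay, within 0% to 22%.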

Compound 4, a percentage reported as inhibition, at one concentration (the size of the read-out at that concentration, not a potency): 17.4%
The estimate for compound 4 lay 8.4 percentage points below the measured number, and the stated range covers the measured number.
By their numbers in this assay, from the lowest: compounds 3 and 1 (each within the scatter of the next); then compounds 2 and 4 (each within the scatter of the next).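

In this assay, the exchange at this place, on an aromatic carbon para to a large group, gives a number 13.6 percentage points higher from compound 1 to compound 4 (beyond the scatter) and so shows that the number at this position responds to the choice of amine side chain. The earlier step saw the bis(2-(dimethylamino)ethyl)amino group only as it entered, with a number 17.3 percentage points lower from compound 2 to compound 3 (beyond the scatter); here the same group leaves and the number moves the opposite way, so in both steps that group goes with the lower number. The two groups have the same count of 11 heavy atoms, so this step does not come with a change in that count, but the entering group has one six-membered non-aromatic ring and 2 hydrogen-bond acceptors in place of 3, and nothing measured here explains the rise.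

The compounds shown leave open whether the ring, the loss of one nitrogen or the shape of the chain carries this step, since all of these change together between compound 1 and compound 4. An open-chain dimethylaminopropyl group with the same methylamino attachment would separate the ring from the chain, and a morpholine ring in place of the piperidine would test whether the ring's atoms matter.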